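Aryl swap on compound 1: furan to methylpyrazole

The compounds below may be only part of what the source reports. "The series", "measured", "known", "first", "only" and "open" are said of these compounds alone.

Measured compounds:
compound 1 `CCN(c1ccc(C#N)c(Cl)c1)c1cc(-c2ccoc2)ccc1C`: 4010 nM
compound 2 `CCN(c1cccc(-n2ccnc2)c1)c1ccc(C#N)c(Cl)c1`: > 30000 nM
compound 3 `Cn1nccc1-c1cccc2c1CCCN2c1ccc(C#N)c(C(F)(F)F)c1`: > 30000 nM

Within the data shown here, in a functional assay on VCaP cells (Homo sapiens) for antiproliferative activity, read by CCK-8 assay, with a stated time of 6 days (a higher number here means a weaker inhibitor, a lower number a stronger inhibitor), compound 1 gives 4010 nM, the only number in the set. For compound 2 the entry > 30000 nM is a limit of the assay, not a number. For compound 3 the entry > 30000 nM is likewise a limit. Two of the three values thus sit at the limit of > 30000 nM in this assay, at which 2 of the 3 values shown sit. Among the measured compounds shown here, compound 1 therefore stands alone as the one compound with a measured value, and no two of the measured compounds differ in only one place, so no measured step is at hand to guide the next one.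

Compound 4 `CCN(c1ccc(C#N)c(Cl)c1)c1cc(-c2ccnn2C)ccc1C` has not yet been measured. It differs from compound 1 by 1-methyl-1H-pyrazol-5-yl in place of furan-3-yl on an aromatic carbon. For the measured compounds named here, with no measured step of this kind available, the change is expected to move the value only modestly, within or slightly beyond the scatter, and if anything toward a weaker inhibitor. The expected step is a 1.5-fold higher number from compound 1 to compound 4 (0.18 log units; within the scatter). In this assay compound 4 is expected to give about 6000 nM, with a range from 1500 nM to 25000 nM.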

Compound 4, half-maximal inhibitory concentration: 1670 nM
Estimate against measurement, compound 4: 3.6-fold (0.56 log units) above; the measured number falls inside the stated range.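

In this assay, among these compounds, the aromatic carbon para to a methyl group and meta to a large group is the first place where a change can be read as a step: 1-methyl-1H-pyrazol-5-yl in place of furan-3-yl gives a 2.4-fold lower number from compound 1 to compound 4 (0.38 log units; beyond the scatter). The step is modest but beyond the scatter, so this position responds to the identity of the five-membered aromatic ring, and a ring with 2 hetero atoms and 2 hydrogen-bond acceptors is accepted here without loss relative to the furan-3-yl ring of compound 1. Compound 2 and compound 3 remain limits of the assay, not numbers, and no steps to them can be read: the limit of > 30000 nM in this assay, at which 2 of the 4 values shown sit.

This single pair does not separate the contribution of the ring methyl group from that of the second ring nitrogen, and it gives no reason for the step. Also open, going by these compounds, is whether the same position would hold or extend this level of activity with the unmethylated pyrazole ring, or with a non-aromatic group such as a morpholine, an amine or a carboxylic acid.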